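Methylation of the phenol in two lactone series

A few compounds are considered here, and "the series" means these few. Any claim that something is new, unique, unknown or untested is made for them only; others in the source may bear on it.

Compound 1 `CC1(/C=C/c2ccccc2O)C=CC(=O)O1` gives 78000 nM in a functional assay on NCI/ADR-RES cells (Homo sapiens) for inhibition, read by sulforhodamine B assay, with a stated time of 48 h; a higher number here means a weaker inhibitor of growth, a lower number a stronger inhibitor of growth; compound 2 `CC1(/C=C/c2cccc(O)c2)C=CC(=O)O1` gives 647000 nM; compound 3 `COc1ccccc1/C=C/C1(C)C=CC(=O)O1` gives 64500 nM.

Compound 3 arises from compound 1 by methyl in place of hydrogen on an oxygen on an aromatic ring, and this step gave a 1.2-fold lower number from compound 1 to compound 3 (0.08 log units; within the scatter). Compound 2 carries the same atoms as compound 1 joined differently; how the two cores differ is not broken down here. Compound 4 `COc1cccc(/C=C/C2(C)C=CC(=O)O2)c1` has not yet been measured in this assay. It arises from compound 2 by methyl in place of hydrogen on an oxygen on an aromatic ring, the same kind of change as from compound 1 to compound 3, at a place described in the same words. The step is therefore expected to be of similar size, a 1.2-fold lower number from compound 2 to compound 4 (0.08 log units; within the scatter), because the earlier step was a 1.2-fold lower number from compound 1 to compound 3 (0.08 log units; within the scatter). Compound 4 is accordingly estimated at 540000 nM, with a range of 250000 nM to 1200000 nM.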

Compound 4, concentration for total growth inhibition: 48600 nM
Beside the measured number, compound 4's estimate is 11-fold (1.05 log units) above it, outside the stated range (below it).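

In this assay, the change from hydroxy to methoxy gave a 13-fold lower number from compound 2 to compound 4 (1.12 log units; beyond the scatter) and so did much more here than on the core of compound 1. The same change therefore did not carry over in size from one core to the other: the same change on two cores in this assay, a 1.2-fold lower number (0.08 log units; within the scatter) from compound 1 to compound 3 and a 13-fold lower number (1.12 log units; beyond the scatter) from compound 2 to compound 4, 11-fold (1.04 log units) apart, beyond the scatter of two such steps. This shows that, for these two cores, the step seen on one did not foretell the step on the other, but two pairs cannot show why the steps differ or how the change would behave on any further core.

The compounds shown leave open whether a longer chain on that oxygen, such as ethoxy, would follow the step to compound 3 or the step to compound 4. They also leave open what an amine in place of the hydroxy would do on either core.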